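The source may hold more compounds than are shown below. What is called first, only, known or untested is meant among the compounds shown, and "the series" means these compounds.

Of the compounds shown here, two share a core and have been tested in a functional assay on the whole organism (Tail, strain ICR) with Mus musculus as the target, in the tail flick test, with a stated time of 150 min, at a dose of 12.5 umol/kg by the oral route; a lower number here means a weaker effect, a higher number a stronger effect of the compound at the dose given. Compound 1, `O=C(CN(c1nc(Cl)nc2[nH]cnc12)C1CC1)NCC(=O)OCc1ccccc1`, gives 6.2% in this assay. Compound 2, `N=C(N)NCCC[C@H](NC(=O)CN(c1nc(Cl)nc2[nH]cnc12)C1CC1)C(=O)O`, gives 6.93% in this assay. The two numbers lie within the usual scatter of each other, so compound 1 cannot be set apart from compound 2 on these data, and both readings sit close to the bottom of the scale. Among the measured compounds shown here, no pair of measured compounds differing in a single place is available, so no measured step can be drawn on.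

Compound 3, `CC(C)[C@H](NC(=O)CN(c1nc(Cl)nc2[nH]cnc12)C1CC1)C(=O)OCc1ccccc1`, has not been measured. It differs from compound 1 in one place: isopropyl in place of hydrogen on a saturated chain carbon bound to an amide-type nitrogen and a carbonyl carbon. For the measured compounds named here, nothing among the measured compounds shows what adding a group of this kind does here, and both measured values are small. The step from compound 1 to compound 3 in this assay is therefore expected to be small and within the scatter, a number 1.8 percentage points higher from compound 1 to compound 3 (within the scatter), with no direction to be read from the data. For compound 3 the value in this assay is estimated at 8%, most likely between 0% and 25%.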

Compound 3, a percentage reported as activity, at one dose (the size of the read-out at that dose, not a potency): 5.43%
The estimate for compound 3 lay 2.6 percentage points above the measured number; the range from low to high includes it.
By their numbers in this assay, from the lowest: compounds 3, 1 and 2 (each within the scatter of the next).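

Among the compounds shown here, compound 3 supplies the first measured step: in this assay, the change gives a number 0.8 percentage points lower from compound 1 to compound 3 (within the scatter). At this saturated chain carbon bound to an amide-type nitrogen and a carbonyl carbon, then, isopropyl in place of hydrogen, which brings in 3 heavy atoms, does not move the read-out beyond the usual scatter, and compound 3 stays in the same low range as compound 1. Nothing among the available data bears on why this change leaves the read-out so little altered.

As far as these compounds go, what remains open is whether a different group at this carbon, such as a methyl, a longer chain, a phenyl ring, an amine or a carboxylic acid, would lift the response clear of the scatter, or whether this position has little bearing on the read-out at all. From the compounds shown here alone, it is also open whether the benzyl ester shared by compound 1 and compound 3 matters, as a free carboxylic acid in its place would show, and whether any of these low readings would change at another dose or time.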